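The compounds below may be only part of what the source reports. "The series", "measured", "known", "first", "only" and "open" are said of these compounds alone.

Measured so far in a functional assay on HEK293 cells for negative allosteric modulation of metabotropic glutamate receptor 5 (Homo sapiens), read by fluorescence and calcium flux, with a stated time of 2 min; on this read-out lower numbers stand for stronger inhibition and higher numbers for weaker inhibition:
compound 1 `O=C(c1ccccc1)N1CCc2oc(-c3ccc(Cl)cn3)nc2C1` gives 32 nM
compound 2 `O=C(c1ccccc1)N1CCc2oc(-c3ccc(Br)cn3)nc2C1` gives 174 nM

Compound 2 stands at the higher of the two numbers in this assay; its nearest neighbour, compound 1, sits lower, the gap being a 5.4-fold higher number from compound 1 to compound 2 (0.74 log units; beyond the scatter) and beyond the scatter. Compound 3 `N#Cc1ccc(-c2nc3c(o2)CCN(C(=O)c2ccccc2)C3)nc1` is not yet measured. It differs from compound 2 by cyano in place of bromo on an aromatic carbon. Going by the values given here, only one measured step touches this carbon, the halogen exchange a 5.4-fold higher number from compound 1 to compound 2 (0.74 log units; beyond the scatter), which shows that the group at this position shifts the number beyond the scatter; no measured pair covers cyano here, so the direction of the cyano step is not fixed by the data. Since a change at the same carbon already moved the read-out by a modest amount, a step of comparable size is expected, most likely back toward the lower number of compound 1. Compound 3 is therefore estimated at 60 nM, with a range of 15 nM to 250 nM, meaning an expected step of a 2.9-fold lower number from compound 2 to compound 3 (0.46 log units; beyond the scatter).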

Compound 3, half-maximal inhibitory concentration: 237 nM
The estimate for compound 3 lay 4.0-fold (0.60 log units) below the measured number, within the range that was stated.
By their numbers in this assay, from the lowest: compound 1; then compounds 2 and 3 (each within the scatter of the next).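

Exchanging 5-bromopyridin-2-yl for 5-cyanopyridin-2-yl gives a step that cannot be separated from the scatter (a 1.4-fold higher number from compound 2 to compound 3 (0.13 log units; within the scatter)), even though cyano brings an extra heavy atom and a hydrogen-bond acceptor that bromo lacks. Among the three groups now seen on this aromatic carbon, chloro alone stands apart, with both other groups giving weaker inhibition (a 7.4-fold higher number from compound 1 to compound 3 (0.87 log units; beyond the scatter); a 5.4-fold higher number from compound 1 to compound 2 (0.74 log units; beyond the scatter)), so the position does not simply separate halogens from non-halogens. No supporting data bear on why chloro differs from bromo and cyano here.

Fluoro, a methyl, a methoxy or an amine on this carbon would show whether the advantage of chloro is narrow or extends to other groups. The compounds shown also leave open whether this ranking holds with changes elsewhere on the shared core.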